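This account rests on a few compounds, and the source may have more. Where it says the series, first, only, none or still open, it means among the compounds named here.

In a toxicity assay on THP-1 cells (Homo sapiens) for inhibition (on this read-out lower numbers stand for higher toxicity in this test and higher numbers for lower toxicity in this test), compound 1 (`COc1ccc(-c2cnc(NC(=O)c3ccccc3F)n2C)cc1`) gives > 100000 nM as a limit of the assay, not a number. Compound 2 (`COc1ccc(-c2cnc(NC(=O)C3CCCCC3)n2C)cc1`) gives > 100000 nM, which is also a limit. Compound 2 therefore has no exact position, and it shares that limit with compound 1 (the limit of > 100000 nM in this assay, at which 2 of the 2 values shown sit). For the measured compounds named here, the one measured step (a step that the two limits leave unreadable from compound 1 to compound 2) has no readable size, so it offers no number to carry forward. Compound 3 (`COc1ccc(-c2cnc(NC(=O)c3cccc(Br)c3)n2C)cc1`) differs from compound 2 by a single change (3-bromophenyl in place of cyclohexyl on a carbonyl carbon) on a carbonyl carbon whose other neighbour is an amide-type nitrogen. Compound 1, with 2-fluorophenyl at that place, gives > 100000 nM as a limit, so no step beyond the scatter is expected in this assay, though any readable shift could only run toward lower numbers. Compound 3 is expected at 100000 nM with an estimated range from 30000 nM to 100000 nM in this read-out. The expected step reads a number no higher from compound 2 to compound 3 (the limit leaves the size open) on this estimate.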

Compound 3, half-maximal cytotoxic concentration: > 100000 nM
Compound 3: a limit, no number (the forecaster's own chance of this, stated with the estimate: 85%); the middle value sits exactly at the limit.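

Compound 3 also gives only a limit of the assay, so no step among compound 1, compound 2 and compound 3 can be read in this assay: the limit of > 100000 nM in this assay, at which 3 of the 3 values shown sit.

The compounds shown leave open whether cyclohexyl, 2-fluorophenyl and 3-bromophenyl on the carbonyl carbon differ at all in this assay.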